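This account rests on a few compounds, and the source may have more. Where it says the series, first, only, none or still open, it means among the compounds named here.

In a functional assay on MCF7 cells (Homo sapiens) for antiproliferative activity, read by MTT assay, with a stated time of 72 h (a higher number here means a weaker inhibitor, a lower number a stronger inhibitor), compound 1 `CCCSc1nc(N/N=C(\C)c2ccccc2O)c2nnn(Cc3ccccc3)c2n1` gives 11000 nM. Compound 2 `CCCSc1nc(N/N=C/c2ccc(Br)cc2)c2nnn(Cc3ccccc3)c2n1` gives only a limit, > 64000 nM, and so stands at the limit of > 64000 nM in this assay, at which 1 of the 2 values shown sits. Compound 3 `CCCSc1nc(N/N=C(\C)c2ccccc2)c2nnn(Cc3ccccc3)c2n1` follows from compound 2 by a group of 9 heavy atoms (8 carbon, 1 nitrogen; one six-membered aromatic ring of carbon only) in place of a group of 9 heavy atoms (7 carbon, 1 nitrogen, 1 bromine; one six-membered aromatic ring of carbon only), on a nitrogen on an aromatic ring. The bromine leaves, and the entering group stays on a nitrogen on an aromatic ring. Going by the values given here, one measured step bears on this change: an at least 5.8-fold higher number from compound 1 to compound 2 (0.76 log units; beyond the scatter), which replaced a group at that same place and lies beyond the scatter. Among the compounds with values here, with only this step and no number for compound 2 as a starting point, the evidence is thin. A small move towards a lower number in this assay is expected, and it may not clear the scatter. The expected change is an at least 1.6-fold lower number from compound 2 to compound 3 (0.22 log units; that floor lies within the scatter). For compound 3 the estimated value is 38000 nM, with an expected range of 15000 nM to 64000 nM.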

Compound 3, half-maximal inhibitory concentration: 32100 nM
Beside the measured number, compound 3's estimate is 1.2-fold (0.07 log units) above it, within the range that was stated.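

The hydroxy group now has a reading of its own: with hydrogen in place of hydroxy on an aromatic carbon as the only difference, this assay shows a 2.9-fold higher number from compound 1 to compound 3 (0.47 log units; beyond the scatter) and that step lies beyond the scatter. Of the three compounds, compound 1 is the only one carrying hydroxy and has the lowest number, and both steps away from it lie beyond the scatter. The step of an at least 1.9-fold lower number from compound 2 to compound 3 (0.29 log units; that floor lies within the scatter) rests on a limit and its floor lies within the scatter, so it gives no size for the exchange of the bromine-bearing group.

Going by these compounds, what a methoxy or an amine in place of the hydroxy would give stays open. So does the true size of the step from the bromine-bearing group, which needs a number rather than a limit for compound 2.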